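The source may hold more compounds than are shown below. What is called first, only, known or untested is meant among the compounds shown, and "the series" means these compounds.

Measured in a functional assay on SK-OV-3 cells (Homo sapiens) for cytotoxicity, read by MTT assay; on this read-out lower numbers stand for stronger inhibition and higher numbers for weaker inhibition:
compound 1 `N#Cc1c(Nc2ccc(Cl)cc2)c(F)c2nc(N)nc(N)c2c1F` gives 4.8 ug/mL
compound 2 `N#Cc1c(NCc2ccccc2)c(F)c2nc(N)nc(N)c2c1F` gives 11 ug/mL
compound 3 `CCN(CC)c1c(C#N)c(F)c2c(N)nc(N)nc2c1F` gives 1 ug/mL

Compound 2 stands highest of the three numbers in this assay. Its nearest neighbour is compound 1, a 2.3-fold higher number from compound 1 to compound 2 (0.36 log units; beyond the scatter); its furthest is compound 3, an 11-fold lower number from compound 2 to compound 3 (1.04 log units; beyond the scatter). Between the other two, a 4.8-fold lower number from compound 1 to compound 3 (0.68 log units; beyond the scatter). Every one of these steps changes the group on the same aromatic carbon, the one that carries benzylamino in compound 2.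

Compound 4 `N#Cc1c(NCc2ccccc2)c(F)c2nc(N)nc(N)c2c1NCc1ccccc1` differs from compound 2 elsewhere: benzylamino in place of fluoro on an aromatic carbon. Going by the values given here, no measured step bears on this position; the three steps all concern the group that compound 4 keeps, so they give no direction for this change, and their sizes, modest to large, only mark how far a single change on this core can move the number. With nothing pointing either way, compound 4 is expected to sit close to compound 2, with a step of a 1.3-fold higher number from compound 2 to compound 4 (0.10 log units; within the scatter) that need not go beyond the scatter. The estimate for compound 4 is therefore 14 ug/mL, within a range of 5 ug/mL to 40 ug/mL.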

Compound 4, half-maximal inhibitory concentration: 2.5 ug/mL
For compound 4 the middle estimate is 5.6-fold (0.75 log units) above the measured one; the whole stated range lies above it.
By their numbers in this assay, from the lowest: compound 3; then compounds 4 and 1 (each within the scatter of the next); then compound 2.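

The position that carries fluoro in compound 2, ortho to a cyano group, proves responsive in this assay: the exchange for benzylamino gives a 4.4-fold lower number from compound 2 to compound 4 (0.64 log units; beyond the scatter). The entering group brings 8 heavy atoms in place of 1, along with a six-membered aromatic ring and a hydrogen-bond donor, yet the number moves toward stronger inhibition, so a substituent of this size is accepted here without loss. No available measurement explains this step.

On these data alone, whether the gain belongs to benzylamino itself or would follow from other replacements of fluoro remains open, and a methoxy group or a small primary amine at this position would help separate the two. Also open, as far as these compounds go, is whether the same exchange would act alike on the core of compound 3, which carries diethylamino.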